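A few compounds are considered here, and "the series" means these few. Any claim that something is new, unique, unknown or untested is made for them only; others in the source may bear on it.

Compound 1 `Cc1ccccc1NC(=O)Nc1cccc(CNc2ncnc3ccccc23)c1`: in a functional assay on MGC-803 cells (Homo sapiens) for antiproliferative activity, read by MTT assay (a lower number here means a stronger inhibitor, a higher number a weaker inhibitor), compound 1 reaches only > 50000 nM, which is a limit of the assay rather than a number.
Compound 2 `COc1ccc(NC(=O)Nc2cccc(CNc3ncnc4ccccc34)c2)cc1`: compound 2 gives 27300 nM.
Compound 3 `COc1cc2ncnc(NCc3cccc(NC(=O)Nc4ccccc4)c3)c2cc1OC`: compound 3 gives 10000 nM.

Compound 3 holds the lowest of the two numbers; its nearest neighbour is compound 2, whose number is higher by a gap beyond the scatter. Compound 1 stands apart at the limit of > 50000 nM in this assay, at which 1 of the 3 values shown sits.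

Compound 4 `COc1ccccc1NC(=O)Nc1cccc(CNc2ncnc3cc(OC)c(OC)cc23)c1` differs from compound 3 by methoxy in place of hydrogen on an aromatic carbon. For the measured compounds named here, only one measured step touches this region of the molecule: an at least 1.8-fold lower number from compound 1 to compound 2 (0.26 log units; that floor lies within the scatter). That step alters both the group and its place on the terminal ring, so it bears on the new step only indirectly; it shows that the compound carrying the 2-methylphenyl sits at the limit, while the 4-methoxyphenyl gives a number. Compound 4 is therefore expected to show a modest weakening, a 1.8-fold higher number from compound 3 to compound 4 (0.26 log units; within the scatter), of a size that may not exceed the scatter. The estimate for compound 4 is 18000 nM, with a range from 6000 nM to 50000 nM.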

Compound 4, half-maximal inhibitory concentration: 7710 nM
The estimate for compound 4 lay 2.3-fold (0.37 log units) above the measured number, within the range that was stated.
By their numbers in this assay, from the lowest: compounds 4 and 3 (each within the scatter of the next); then compound 2. At a limit, above all of these: compound 1.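

In this assay, the change from phenylcarbamoyl to (2-methoxyphenyl)carbamoyl places methoxy on an aromatic carbon ortho to a large group and gives a 1.3-fold lower number from compound 3 to compound 4 (0.11 log units; within the scatter). For the compounds shown here, this is the first step on that ring in which a single group replaces hydrogen, and it shows that, with the core of compound 3, this position accepts methoxy with no change that stands out from the scatter. Compound 1 remains the only compound at a limit, which is not a number: the limit of > 50000 nM in this assay, at which 1 of the 4 values shown sits.

As far as these compounds go, whether an amine, a carboxylic acid or a longer chain such as ethoxy at this position would also leave the number within the scatter stays open. So does whether methoxy here would give the same result on the core of compound 1.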